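The source may hold more compounds than are shown below. What is called first, only, known or untested is meant among the compounds shown, and "the series" means these compounds.

Measured in an ADME assay on Vero cells (Chlorocebus sabaeus) for cytotoxicity, read by neutral red uptake, with a stated time of 3 days; on this read-out higher numbers stand for lower toxicity in this test and lower numbers for higher toxicity in this test:
- compound 1 `CNCCCNC(=O)c1cc(C2CC2)nc2c1cnn2C(C)C`: 281000 nM
- compound 2 `CCn1ncc2c(C(=O)NCCN(C)C)cc(C3CC3)nc21`: > 300000 nM (a limit of the assay, not a number)

Compound 2 stands at a limit, with > 300000 nM. Compound 3 `CCCn1ncc2c(C(=O)NCCN(C)C)cc(C3CC3)nc21` carries one change from compound 2: methyl in place of hydrogen on a saturated chain carbon, two bonds along the chain from an aromatic nitrogen, which turns ethyl to propyl. Among the compounds with values here, no measured pair isolates this change, and compound 1 gives the only actual number, 281000 nM. The expected change in this assay, an at least 1.1-fold lower number from compound 2 to compound 3 (0.04 log units; that floor lies within the scatter), is none beyond the scatter, with any drift towards lower numbers. For compound 3 the estimate is 270000 nM, with an expected range from 140000 nM to 300000 nM.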

Compound 3, half-maximal cytotoxic concentration: 111000 nM
Beside the measured number, compound 3's estimate is 2.4-fold (0.39 log units) above it, and the stated range ends above it.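

In this assay, within the data shown here, the ethyl to propyl change gives an at least 2.7-fold lower number from compound 2 to compound 3 (0.43 log units; beyond the scatter), so the earlier compounds did not reveal that a single added methyl at this saturated chain carbon can shift the read-out towards higher toxicity in this test. The true size of this step remains unknown, because compound 2 stands at a limit of the assay, not a number: the limit of > 300000 nM in this assay, at which 1 of the 3 values shown sits.

The compounds shown leave open whether a longer chain, such as butyl, would continue this shift. They also leave open whether a hydroxyl group at this carbon would have the same effect.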